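Propoxy in place of acetoxy on a flavonol core: tolerability

The source may hold more compounds than are shown below. What is called first, only, known or untested is meant among the compounds shown, and "the series" means these compounds.

Compound 1 `COc1ccc2oc(-c3cccc(-c4ccc(OC)c(OC)c4)c3)c(O)c(=O)c2c1`: in an ADME assay on THP-1 cells (Homo sapiens) for cytotoxicity, read by MTT assay (a lower number here means that less compound is tolerated, a higher number that more compound is tolerated), compound 1 gives >= 25000 nM, a limit of the assay rather than a number.
Compound 2 `COc1ccc2oc(-c3csc4ccccc34)c(OC(C)=O)c(=O)c2c1`: in this assay compound 2 gives >= 12500 nM, again a limit.
Compound 3 `CCCCC(=O)Oc1c(-c2csc3ccccc23)oc2ccc(OC)cc2c1=O`: in this assay compound 3 gives >= 12500 nM, also a limit.

For the measured compounds named here, compound 2 therefore stands nowhere definite on the scale: its value is only a limit, and the two other values shown are limits as well, so no compound can be ranked against another. Going by the values given here, the one measured step between compounds differing in a single place, a step that the two limits leave unreadable from compound 2 to compound 3, cannot be read, because the limit of >= 12500 nM in this assay, at which 2 of the 3 values shown sit, sits at both of its ends.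

Compound 4 `CCCOc1c(-c2csc3ccccc23)oc2ccc(OC)cc2c1=O` differs from compound 2 by propyl in place of acetyl on an oxygen on an aromatic ring. Among the compounds with values here, no measured step bears on this change with a readable size, so no step beyond the scatter is expected in this assay in either direction. Compound 4 is expected to give 25000 nM, between 12500 nM and 80000 nM, most likely reported as a limit again. The step expected from compound 2 to compound 4 is a step that the limit leaves unreadable from compound 2 to compound 4.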

Compound 4, half-maximal cytotoxic concentration: >= 12500 nM
Compound 4: a limit, no number (the forecaster's own chance of this, stated with the estimate: 80%); the middle value is on the limit's open side.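

The steps from compound 2 and from compound 3 to compound 4 cannot be read, because all three compounds sit at the same limit: the limit of >= 12500 nM in this assay, at which 3 of the 4 values shown sit.

The compounds shown leave open whether acetoxy to propoxy changes anything in this assay, as none of them has a value that is an actual number.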